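Oxygen-to-sulfur swap in the side-chain ring of compound 1

A few compounds are considered here, and "the series" means these few. Any claim that something is new, unique, unknown or untested is made for them only; others in the source may bear on it.

Compound 1 `O=S(=O)(CC1=NCCO1)C1C(c2ccc(Cl)cc2)=NOC1c1ccc(Cl)cc1` is reported in a functional assay, tested at 50 ug/mL (a lower number here means a weaker effect, a higher number a stronger effect of the compound at the concentration tested), only as "not active" (no number reported), with no number given, so its standing cannot be placed on the scale. Compound 2 `COc1ccc(-c2nn(-c3ccccc3)c(-c3ccc(C)cc3)c2S(=O)(=O)CC2=NCCS2)cc1` likewise is reported there as "not active" (no number reported). Compound 3 `Cc1ccc(C2CNN=C2S(=O)(=O)CC2=NCCS2)cc1` does give a read-out: in this assay compound 3 gives 39.8%. Compound 4 `O=S(=O)(CC1=NCCS1)C1C(c2ccc(Cl)cc2)=NOC1c1ccc(Cl)cc1` carries the change from compound 1 marked as a group of 5 heavy atoms (3 carbon, 1 nitrogen, 1 sulfur; one five-membered non-aromatic ring with 2 hetero atoms) in place of a group of 5 heavy atoms (3 carbon, 1 nitrogen, 1 oxygen; one five-membered non-aromatic ring with 2 hetero atoms), on a saturated chain carbon bound to a sulfonyl sulfur. The same five-membered ring with a sulfur occurs in compound 3, which is active, and in compound 2, which is not, so the sulfur ring alone does not decide the outcome. A small upward step from compound 1, possibly not beyond the scatter, is expected. For compound 4 an activity of 15% is estimated, within 0% to 40%.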

Compound 4, a percentage reported as activity, at one concentration (the size of the read-out at that concentration, not a potency): "not active" (no number reported)
The entry for compound 4 holds no number; no gap can be computed for the estimate.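

Compound 1 and compound 4 both lack a number, so no step can be read between them. No measured evidence bears on this result. From the compounds shown here alone, whether swapping the ring oxygen for sulfur changes activity at all stays open.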